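This account rests on a few compounds, and the source may have more. Where it says the series, first, only, none or still open, it means among the compounds named here.

In a functional assay on aorta (Rattus norvegicus, strain Wistar) for inhibition (a lower number here means that less compound is needed, a higher number that more compound is needed for the effect), compound 2 `O=C(CO[N+](=O)[O-])NNC(=O)c1ccc(-n2[nH]c(=O)cc2-c2ccccc2)cc1` gives 26.7 ug/mL. Of the three numbers recorded here this is the second highest: compound 3 `CCOC(=O)c1c(-c2ccc([N+](=O)[O-])cc2)n(-c2ccc(C(=O)NNC(=O)CO[N+](=O)[O-])cc2)[nH]c1=O` gives 28.2 ug/mL in this assay, within the scatter of compound 2, and compound 1 `O=C(CO[N+](=O)[O-])NNC(=O)c1ccc(-n2[nH]c(=O)cc2-c2ccccc2O)cc1` gives 17.8 ug/mL, also within the scatter. Within the data shown here, the one measured step, a 1.5-fold higher number from compound 1 to compound 2 (0.18 log units; within the scatter), concerns a hydroxy group on a distant aromatic carbon and does not go beyond the scatter.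

Compound 4 `CCOC(=O)c1c(-c2ccccc2)n(-c2ccc(C(=O)NNC(=O)CO[N+](=O)[O-])cc2)[nH]c1=O` is obtained from compound 2 by the change (ethoxycarbonyl in place of hydrogen on an aromatic carbon). Among the measured compounds shown here, no measured step touches this place on the core. For the measured compounds named here, compound 3 carries the same ethoxycarbonyl group, but it differs from compound 2 in a second place as well, so its comparison with compound 2 shows only two values within the scatter of each other. With nothing to indicate otherwise, the step of a 1.0-fold higher number from compound 2 to compound 4 (0.00 log units; within the scatter) is expected to stay within the scatter. Compound 4 is therefore estimated at 27 ug/mL in this assay, with a range from 13 ug/mL to 55 ug/mL.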

Compound 4, half-maximal effective concentration: 35.5 ug/mL
Estimate against measurement, compound 4: 1.3-fold (0.12 log units) below; the measured number falls inside the stated range.
By their numbers in this assay, from the lowest: compounds 1, 2, 3 and 4 (each within the scatter of the next).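

In this assay, among these compounds, the ethoxycarbonyl group on an aromatic carbon of the five-membered aromatic ring, next to the ring atom that bears a phenyl group, gives a 1.3-fold higher number from compound 2 to compound 4 (0.12 log units; within the scatter), the first reading of this position with only one place changed. A group of 5 heavy atoms can therefore replace hydrogen here without the number leaving the scatter. With ethoxycarbonyl in place, the change on the outer aromatic ring gives a 1.3-fold higher number from compound 3 to compound 4 (0.10 log units; within the scatter), so the nitro group also makes no difference beyond the scatter, and nothing available accounts for either step.

As far as these compounds go, whether a carboxylic acid, an amine or a longer alkyl chain at this position would also stay within the scatter remains open. So does whether the hydroxy group of compound 1 would behave the same way alongside ethoxycarbonyl.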